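This account rests on a few compounds, and the source may have more. Where it says the series, first, only, none or still open, it means among the compounds named here.

Measured compounds:
Compound 1 `Nc1nc(NCCNc2ncc(-c3ncc[nH]3)c(-c3ccccc3Cl)n2)ccc1[N+](=O)[O-]` — > 0.5 h in an ADME assay on microsomes from liver (Canis lupus familiaris) for metabolic stability; a higher number here means that the compound lasts longer, a lower number that the compound disappears faster
Compound 2 `Nc1nc(NCCNc2ncc(-c3ncc[nH]3)c(-c3ccccc3Br)n2)ccc1[N+](=O)[O-]` — > 0.5 h
Compound 3 `Nc1nc(NCCNc2ncc(-c3ncc[nH]3)c(-c3ccc(F)cc3Cl)n2)ccc1[N+](=O)[O-]` — > 0.5 h

Three compounds share a core and differ only in the halogen pattern on one phenyl ring. In this assay compound 1 gives > 0.5 h, which is a limit of the assay and not a number. Compound 2 likewise gives > 0.5 h, again a limit. Compound 3 gives > 0.5 h, also a limit. Because (the limit of > 0.5 h in this assay, at which 3 of the 3 values shown sit), none of the steps between them can be read: the change bromo in place of chloro on an aromatic carbon gives a step that the two limits leave unreadable from compound 1 to compound 2, the change fluoro in place of hydrogen on an aromatic carbon gives a step that the two limits leave unreadable from compound 1 to compound 3, and a step that the two limits leave unreadable from compound 2 to compound 3 is equally unreadable.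

Compound 4 `Nc1nc(NCCNc2ncc(-c3ncc[nH]3)c(-c3ccc(F)cc3Br)n2)ccc1[N+](=O)[O-]` has not yet been measured in this assay. It differs from compound 3 by bromo in place of chloro on an aromatic carbon, the same kind of change as that from compound 1 to compound 2, though here the place is also meta to a fluoro group. Since that earlier step that the two limits leave unreadable from compound 1 to compound 2 cannot be sized, the expectation for compound 4 rests only on all three measured values sitting at the limit (the limit of > 0.5 h in this assay, at which 3 of the 3 values shown sit). A step that the limit leaves unreadable from compound 3 to compound 4 is expected from compound 3 to compound 4, and compound 4 is estimated at 1 h, most likely again reported only as a limit.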

Compound 4, half-life: > 0.5 h
Compound 4 gave a limit, no number (the forecaster's own chance of this, stated with the estimate: 80%); the middle value does not contradict the limit.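

In this assay compound 4 gives > 0.5 h, which is a limit of the assay and not a number. The steps to compound 4 from compound 1, compound 2 and compound 3 therefore cannot be read, because all four compounds share one limit: the limit of > 0.5 h in this assay, at which 4 of the 4 values shown sit.

The compounds shown leave open how long each one actually lasts, and whether bromo in place of chloro or fluoro in place of hydrogen alters that at all.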